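The source may hold more compounds than are shown below. What is called first, only, known or untested is meant among the compounds shown, and "the series" means these compounds.

In a functional assay on the whole organism (strain Kunming) with Mus musculus as the target, with a stated time of 0.5 h (a lower number here means that less compound is needed, a higher number that more compound is needed for the effect), compound 1 (`COc1cc(OC)c(OC)cc1/C=C/COC(=O)/C=C/c1ccc(OC)c(OC)c1`) gives 418 umol/kg and compound 2 (`COc1cc(OC)c(OC)cc1/C=C/COC(=O)/C=C/c1c(OC)ccc(OC)c1OC`) gives 476 umol/kg, so the two values lie within the scatter of each other. Compound 3 (`COc1cc(OC)c(OC)cc1/C=C/COC(=O)/C=C/c1cccc(Br)c1`) carries 3-bromophenyl in place of 3,4-dimethoxyphenyl on a double-bonded chain carbon bound to a double-bonded chain carbon. Among the compounds with values here, no measured compound carries the 3-bromophenyl group, so the data give no step for this change. No shift beyond the scatter is expected in this assay, in either direction. The estimated step is a 1.1-fold lower number from compound 1 to compound 3 (0.03 log units; within the scatter). For compound 3 the expected value is 390 umol/kg, with an estimated range of 180 umol/kg to 850 umol/kg.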

Compound 3, dose for half-maximal effect: > 461 umol/kg
Compound 3: a limit, no number; the forecaster's own chance of this, stated with the estimate: 10%; at least 1.1-fold (0.07 log units) between middle value and limit.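

In this assay, 3-bromophenyl in place of 3,4-dimethoxyphenyl on a double-bonded chain carbon bound to a double-bonded chain carbon gives an at least 1.1-fold higher number from compound 1 to compound 3 (0.04 log units; that floor lies within the scatter). Compound 3 gives only a limit, > 461 umol/kg, not a number. The step therefore fixes a floor and no size, so the change may lie within the scatter or beyond it, and among the compounds shown only compound 3 ends in a limit: the limit of > 461 umol/kg in this assay, at which 1 of the 3 values shown sits.

On these data alone, whether removing the methoxy groups or adding the bromine sets this result stays open. The effect of an amine or a carboxylic acid on this ring is also unknown.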